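This account rests on a few compounds, and the source may have more. Where it says the series, first, only, none or still open, it means among the compounds named here.

Compound 2 `C=CCc1ccc2ccccc2c1O` gives the lowest number among the three measured compounds in an assay on RBL-1 cells with Polyunsaturated fatty acid 5-lipoxygenase (Rattus norvegicus) as the target (a lower number here means a stronger inhibitor, a higher number a weaker inhibitor), at 56 nM. Compound 3 `Cc1cc(C)c2ccc(Cc3ccccc3)c(O)c2c1` stands within the usual scatter of it, giving 62 nM, whereas compound 1 `CC(C)(C)c1ccc2ccccc2c1O`, with 180 nM, lies further off. Among the compounds with values here, the only measured step between single-point neighbours is a 3.2-fold lower number from compound 1 to compound 2 (0.51 log units; beyond the scatter), which concerns a change of the whole substituent on the aromatic carbon.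

Compound 4 `O=C(O)CCCCc1ccc2ccccc2c1O` differs from compound 2 by 3-carboxypropyl in place of vinyl on a saturated chain carbon bound to an aromatic carbon. Within the data shown here, no measured step touches the end of that chain, so the change from compound 2 to compound 4 has no direct precedent here; the step from compound 1 to compound 2 shows only that substituent identity at this position can move this assay by a modest amount. The expectation is therefore a modest step upward in this assay, a 2.7-fold higher number from compound 2 to compound 4 (0.43 log units; beyond the scatter), with wide uncertainty. Compound 4 is estimated at 150 nM in this assay, expected between 40 nM and 600 nM.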

Compound 4, half-maximal inhibitory concentration: 4200 nM
Beside the measured number, compound 4's estimate is 28-fold (1.45 log units) below it; the whole stated range lies below it.
By their numbers in this assay, from the lowest: compounds 2 and 3 (each within the scatter of the next); then compound 1; then compound 4.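

In this assay, within the data shown here, the change to 3-carboxypropyl in place of vinyl gives a 75-fold higher number from compound 2 to compound 4 (1.88 log units; beyond the scatter) and so is a large step, whereas the only earlier step, a 3.2-fold lower number from compound 1 to compound 2 (0.51 log units; beyond the scatter) was modest. The earlier compounds shown here showed only a change of the whole substituent on the aromatic carbon, while this result shows that a change on a saturated chain carbon bound to an aromatic carbon can move the number much further. Nothing available bears on the reason for a step of this size.

The compounds shown leave open whether the carboxylic acid or the longer chain accounts for the rise, as 3-carboxypropyl brings both at once. A plain butyl chain, a methyl ester or an amine in its place would help to separate the two.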